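Benzamide ring swap on the shared core: compound 3

The source may hold more compounds than are shown below. What is called first, only, known or untested is meant among the compounds shown, and "the series" means these compounds.

Measured so far:
compound 1 `O=C(Nc1cc(-c2ccccc2)nn1-c1ccccc1)c1ccccc1` gives 4180 nM in an assay on HEK293 cells for displacement of a labelled ligand from metabotropic glutamate receptor 5 (Rattus norvegicus); a higher number here means a weaker inhibitor, a lower number a stronger inhibitor
compound 2 `O=C(Nc1cc(-c2ccccc2)nn1-c1ccccc1)c1ccc(C(F)(F)F)cc1` gives 990 nM in this assay

For the measured compounds named here, compound 2 stands at the lower of the two numbers; its nearest neighbour is compound 1, and the single measured step between them, a 4.2-fold lower number from compound 1 to compound 2 (0.63 log units; beyond the scatter), is the only change on this ring seen so far.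

Compound 3 `COc1cc(OC)cc(C(=O)Nc2cc(-c3ccccc3)nn2-c2ccccc2)c1` is the next variation on the same ring: 3,5-dimethoxyphenyl in place of 4-(trifluoromethyl)phenyl on a carbonyl carbon. Going by the values given here, no measured step touches a dimethoxy pattern on this ring, so the only guide is that a substituent change on this ring moved the number by a 4.2-fold lower number from compound 1 to compound 2 (0.63 log units; beyond the scatter), which is modest. The unsubstituted ring of compound 1 and the substituted ring of compound 2 bracket what is known; a step of similar size in either direction is plausible, and a mild rise back toward compound 1 is expected, a 2.0-fold higher number from compound 2 to compound 3 (0.31 log units; beyond the scatter). For compound 3 the expected value in this assay is 2000 nM, with a range from 600 nM to 7000 nM.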

Compound 3, inhibition constant: > 10000 nM
Compound 3 ended at the assay's limit; the forecaster's own chance of this, stated with the estimate: 10%; middle value at least 5.0-fold (0.69 log units) away from the limit.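

Compound 3 gives a limit of the assay and not a number in this assay: the limit of > 10000 nM in this assay, at which 1 of the 3 values shown sits.

Even as a limit, the 3,5-dimethoxyphenyl group on the carbonyl carbon reads as a loss against both earlier rings, with an at least 10-fold higher number from compound 2 to compound 3 (1.00 log units; beyond the scatter) and an at least 2.3-fold higher number from compound 1 to compound 3 (0.37 log units; beyond the scatter). For the compounds shown here, the only earlier step on this ring, a 4.2-fold lower number from compound 1 to compound 2 (0.63 log units; beyond the scatter), ran toward a lower number, so a change at this position is now seen to move the number in either direction, and substitution as such does not lower it.

On these data alone, the true value of compound 3 stays unknown, so both new steps give only a minimum size. As far as these compounds go, whether a single methoxy group would behave like the pair stays open, as does the effect of an amine or a carboxylic acid on this ring.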